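Five-Membered Ring for Six-Membered on a Soluble Core

The source may hold more compounds than are shown below. What is called first, only, known or untested is meant among the compounds shown, and "the series" means these compounds.

Measured compounds:
compound 1, `Cc1cc(NCc2ccccn2)n2nc(C)c(-c3ccc(F)cc3)c2n1`: < 5000 nM (a limit of the assay, not a number)
compound 2, `Cc1cc(NCc2nccn2C)n2nc(C)c(-c3ccccc3)c2n1`: 26900 nM
compound 3, `Cc1cc(NCc2ccccn2)n2nc(C)cc2n1`: > 200000 nM (a limit of the assay, not a number)

In a physicochemical assay for solubility, read by HPLC, using the shake flask method, measured as kinetic solubility, with a stated time of 2 h, at pH 7.4 (on this read-out higher numbers stand for higher solubility and lower numbers for lower solubility), compound 3 returns only > 200000 nM, which is a limit of the assay rather than a number, so compound 3 stands at the top of what this assay reports here. Compound 1 returns < 5000 nM, likewise a limit. Compound 2 gives 26900 nM. Within the data shown here, the single measured step that reaches compound 3 is an at least 40-fold higher number from compound 1 to compound 3 (1.60 log units; beyond the scatter), a large rise that ends at the limit (the limit of > 200000 nM in this assay, at which 1 of the 3 values shown sits).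

Compound 4, `Cc1cc(NCc2nccn2C)n2nc(C)cc2n1`, differs from compound 3 by 1-methyl-1H-imidazol-2-yl in place of pyridin-2-yl on a saturated chain carbon bound to a nitrogen on an aromatic ring. Among the measured compounds shown here, no measured step bears directly on this exchange; the only step on record changes a different part of the core. With compound 3 already at the ceiling, the change from compound 3 to compound 4 is expected to show no step beyond the scatter, a step that the limit leaves unreadable from compound 3 to compound 4. Compound 4 is therefore expected to give about 250000 nM in this assay, within a range of 100000 nM to 600000 nM, most likely again reported as a limit.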

Compound 4, solubility: 182000 nM
Estimate against measurement, compound 4: 1.4-fold (0.14 log units) above; the range from low to high includes it.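

In this assay, among these compounds, hydrogen in place of phenyl on an aromatic carbon gives a modest step of a 6.8-fold higher number from compound 2 to compound 4 (0.83 log units; beyond the scatter) and this is the first step at that carbon with a number at both ends. The earlier step at that carbon, made with pyridin-2-yl on the chain, ran from one limit of the assay to the other, so its size stayed unknown. Compound 3 stands at a limit (> 200000 nM). The exchange of pyridin-2-yl for 1-methyl-1H-imidazol-2-yl therefore reads only as an at least 1.0-fold lower number from compound 3 to compound 4 (0.04 log units; that floor lies within the scatter) and its true size cannot be read.

Still open, as far as these compounds go, is how these two rings compare where both give numbers, since compound 1 and compound 2 differ in more than one place. Also open, from the compounds shown here alone, is how a carboxylic acid or a morpholine in place of hydrogen on that aromatic carbon would read.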